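This account rests on a few compounds, and the source may have more. Where it says the series, first, only, none or still open, it means among the compounds named here.

Compound 1, with the structure `CCCCc1ccc(NC(=O)COc2cc(C)nc3ccc(OC)cc23)cc1`, and compound 2, with the structure `COc1ccc2nc(C)cc(OCC(=O)Nc3ccc4c(c3)CCC4)c2c1`, share the same core and differ only in the group attached to the amide nitrogen. In an ADME assay on liver (Homo sapiens) for metabolic stability, read by LC-MS, using S9 fraction, tested at 2 uM (on this read-out lower numbers stand for a shorter-lived compound and higher numbers for a longer-lived compound), compound 1 gives 0.228 h, and in this assay compound 2 gives 0.195 h. Compound 1 thus has the higher of the two numbers, but the gap to compound 2 lies within the usual scatter of the measurement, so the two compounds cannot be told apart on this read-out.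

Compound 3, with the structure `CCCc1ccc(NC(=O)COc2cc(C)nc3ccc(OC)cc23)cc1`, has not yet been measured. It differs from compound 1 in one place: hydrogen in place of methyl on a saturated chain carbon, three bonds along the chain from an aromatic carbon. Going by the values given here, no pair of measured compounds shows the effect of this change, so there is no measured step to lean on. The expectation is that the step in this assay a 1.1-fold higher number from compound 1 to compound 3 (0.04 log units; within the scatter) stays within the scatter, with no clear direction. On that basis compound 3 is estimated to give 0.25 h in this assay, with a likely range from 0.12 h to 0.5 h.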

Compound 3, half-life in the liver assay: 0.503 h
Compound 3: middle estimate off by 2.0-fold (0.30 log units), on the low side, and the stated range ends below it.
By their numbers in the liver assay, from the lowest: compounds 2 and 1 (each within the scatter of the next); then compound 3.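

In the liver assay, shortening butyl to propyl gives a 2.2-fold higher number from compound 1 to compound 3 (0.34 log units; beyond the scatter), which shows that the half-life responds to the loss of a single carbon at the end of this chain; the swap of the 2,3-dihydro-1H-inden-5-yl group for 4-propylphenyl likewise gives a 2.6-fold higher number from compound 2 to compound 3 (0.41 log units; beyond the scatter), so the group on the amide nitrogen matters here, even though compound 1 and compound 2 could not be told apart. The same shortening does not clearly separate the compounds on solubility: in a physicochemical assay for solubility, read by HPLC, measured as thermodynamic solubility, with a stated time of 24 h, at pH 4 (on this read-out lower numbers stand for lower solubility and higher numbers for higher solubility), compound 1 gives 50000 nM and compound 3 gives 90000 nM, and a 1.8-fold higher number from compound 1 to compound 3 (0.26 log units; within the scatter) stays within the scatter. Nothing available here explains how the single carbon alters the half-life.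

With only butyl and propyl shown at this place, a single pair cannot tell whether the half-life would keep moving the same way with a shorter ethyl or methyl group. From the compounds shown here alone, it is also open whether a chain ending in a hydroxyl or an amine would behave like these plain carbon chains in either read-out.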